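A few compounds are considered here, and "the series" means these few. Any claim that something is new, unique, unknown or untested is made for them only; others in the source may bear on it.

Measured so far:
compound 1, `CN(C)c1ccc(Nc2nccc(-c3ccncc3)n2)cc1`, 3700 nM;
compound 2, `COc1cccc(Nc2nccc(-c3cccs3)n2)c1`, 900 nM;
compound 3, `COc1cccc(Nc2nccc(-c3ccc(C)s3)n2)c1`, 2300 nM.

All three were tested in a functional assay for inhibition, with Homo sapiens as the target; on this read-out lower numbers stand for stronger inhibition and higher numbers for weaker inhibition. Compound 2 and compound 3 share one core, and compound 1 has a different core; the difference between the two cores is not broken down here. The number for compound 2 is lower than that for compound 1, a gap beyond the usual scatter, while compound 1 and compound 3 lie within the scatter of each other, so no order between those two is claimed.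

One structural change appears twice. From compound 2 to compound 3 it is methyl in place of hydrogen on an aromatic carbon, and it gave a 2.6-fold higher number from compound 2 to compound 3 (0.41 log units; beyond the scatter). The unmeasured compound 4, `Cc1cc(-c2ccncc2)nc(Nc2ccc(N(C)C)cc2)n1`, differs from compound 1 by methyl in place of hydrogen on an aromatic carbon. This is the same kind of change, but not the same: in compound 3 the methyl sits on a five-membered aromatic ring with one sulfur, next to the ring sulfur, whereas in compound 4 it sits on a six-membered aromatic ring with two nitrogen, next to the ring nitrogen and meta to a pyridin-4-yl group.

Among the compounds with values here, compound 4 is therefore expected to give a somewhat higher number than compound 1, a step of about a 1.9-fold higher number from compound 1 to compound 4 (0.28 log units; within the scatter), because the one measured example of this change gave a 2.6-fold higher number from compound 2 to compound 3 (0.41 log units; beyond the scatter) and no example at the new place exists. The estimate for compound 4 in this assay is 7000 nM, with a range from 3000 nM to 16000 nM.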

Compound 4, half-maximal inhibitory concentration: > 24000 nM
Compound 4 was reported as a limit; the forecaster's own chance of this, stated with the estimate: 10%; middle value at least 3.4-fold (0.53 log units) away from the limit.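

In this assay compound 4 gives > 24000 nM, which is a limit of the assay and not an exact number. Even so, the step can be read as an at least 6.4-fold higher number from compound 1 to compound 4 (0.81 log units; beyond the scatter), so methyl in place of hydrogen on an aromatic carbon gave a higher number, meaning weaker inhibition, in both examples shown, and the direction of the change held across these two cores. This does not show that the change costs more on one core than on the other, and two examples at different places make no general rule for the series: the same change on two cores in this assay, a 2.6-fold higher number (0.41 log units; beyond the scatter) from compound 2 to compound 3 and an at least 6.4-fold higher number (0.81 log units; beyond the scatter) from compound 1 to compound 4; the limit leaves it open whether they differ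

The compounds shown leave open whether a group other than methyl, such as an ethyl group, a methoxy group or an amine, would give a similar result at the place the methyl holds in compound 4. They also leave open what methyl would do at that same place on the six-membered aromatic ring with 2 nitrogen in compound 2, a comparison that would help to separate the role of the place from the role of the rest of the molecule.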